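From phenyl to pyrimidin-2-yl on the ring nitrogen

This account rests on a few compounds, and the source may have more. Where it says the series, first, only, none or still open, it means among the compounds named here.

Measured so far in a functional assay on MCF7 cells (Homo sapiens) for inhibition, read by MTT assay, with a stated time of 72 h; a lower number here means a stronger inhibitor, a higher number a weaker inhibitor
Compound 1 `CCN1CCN(c2cc(C(F)(F)F)nc(SCc3ccc(C(F)(F)F)cc3)n2)CC1` gives 22000 nM
Compound 2 `FC(F)(F)c1ccc(CSc2nc(N3CCN(c4ccccc4)CC3)cc(C(F)(F)F)n2)cc1` gives > 50000 nM

Compound 2 reads > 50000 nM, which is a limit of the assay and not a number. Compound 3 `FC(F)(F)c1ccc(CSc2nc(N3CCN(c4ncccn4)CC3)cc(C(F)(F)F)n2)cc1` carries pyrimidin-2-yl in place of phenyl on an amine nitrogen in a ring at the same place. For the measured compounds named here, the one measured step at this nitrogen is an at least 2.2-fold higher number from compound 1 to compound 2 (0.35 log units; beyond the scatter), at least modest and beyond the scatter, but it swaps ethyl for phenyl and involves no pyrimidin-2-yl. Little change is therefore expected in this assay, at most a small move toward a lower number. The expected step is an at least 1.1-fold lower number from compound 2 to compound 3 (0.04 log units; that floor lies within the scatter), not clearly beyond the scatter. Compound 3 is estimated at 45000 nM, within an expected range of 18000 nM to 100000 nM.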

Compound 3, half-maximal inhibitory concentration: > 50000 nM
Compound 3 ended at the assay's limit (the forecaster's own chance of this, stated with the estimate: 55%); at least 1.1-fold (0.04 log units) between middle value and limit.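

In this assay, pyrimidin-2-yl on the ring nitrogen repeats what phenyl showed, with a step beyond the scatter: an at least 2.2-fold higher number from compound 1 to compound 3 (0.35 log units; beyond the scatter). The hydrogen-bond acceptors that pyrimidin-2-yl carries and phenyl lacks do not bring compound 3 back within the limit of the assay. The step from compound 2 to compound 3 cannot be read, because both values are limits: the limit of > 50000 nM in this assay, at which 2 of the 3 values shown sit.

From the compounds shown here alone, whether methyl or a longer chain such as butyl on this nitrogen would give a lower number than compound 1 stays open. Going by these compounds, how far compound 2 and compound 3 lie past the limit also stays open.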